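Replacing the acid chain of compound 2 with a fluorinated benzyl group

A few compounds are considered here, and "the series" means these few. Any claim that something is new, unique, unknown or untested is made for them only; others in the source may bear on it.

Measured in a functional assay on a cell-free system (plasma, Oryctolagus cuniculus) for inhibition, with stated times of 5 min, 1 min and 6 min; on this read-out lower numbers stand for stronger inhibition and higher numbers for weaker inhibition:
- Compound 1 `CCOC(=O)c1c(C)nc(-c2cccc(C#N)c2)n1O`: 17600 nM
- Compound 2 `CCOC(=O)c1c(C)nc(-c2cccc(C#N)c2)n1OCCC(=O)O`: > 30000 nM, a limit and not a number

Compound 2 gives only a limit, > 30000 nM. Compound 3 `CCOC(=O)c1c(C)nc(-c2cccc(C#N)c2)n1OCc1ccccc1F` keeps the same core and differs in one place: 2-fluorophenyl in place of carboxymethyl on a saturated chain carbon bound to an oxygen on an aromatic ring. Within the data shown here, one measured step bears on this position, an at least 1.7-fold higher number from compound 1 to compound 2 (0.23 log units; that floor lies within the scatter), where 2-carboxyethyl takes the place of hydrogen. Among the measured compounds shown here, no measured compound carries an aromatic group there, so the expectation stays loose and rests on compound 1 at 17600 nM. The expected change is a modest move toward lower numbers: an at least 2.0-fold lower number from compound 2 to compound 3 (0.30 log units; that floor lies within the scatter). For compound 3 the estimated value is 15000 nM, with an expected range of 5000 nM to 40000 nM.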

Compound 3, half-maximal inhibitory concentration: 8990 nM
Beside the measured number, compound 3's estimate is 1.7-fold (0.22 log units) above it, within the range that was stated.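

In this assay, among these compounds, exchanging the acid chain for 2-fluorobenzyl gives an at least 3.3-fold lower number from compound 2 to compound 3 (0.52 log units; beyond the scatter), the first change on this oxygen that clears the scatter. As far as these compounds go, compound 2 holds a limit and not a number, so the true size of this step stays unknown: the limit of > 30000 nM in this assay, at which 1 of the 3 values shown sits. Set against plain hydrogen, 2-fluorobenzyl gives a 2.0-fold lower number from compound 1 to compound 3 (0.29 log units; within the scatter), so this oxygen carries an aromatic group without a loss of inhibition, but also without a clear gain. Still open, from the compounds shown here alone, is what the fluorine itself contributes, which plain benzyl would test, and how an amine or a longer chain would behave on this oxygen.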